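Cyclohexyl removal in the furan-3-yl series: cytotoxicity notes

The source may hold more compounds than are shown below. What is called first, only, known or untested is meant among the compounds shown, and "the series" means these compounds.

In an ADME assay on MT4 cells (Homo sapiens) for cytotoxicity, read by MTT assay, with a stated time of 96 h (on this read-out lower numbers stand for higher toxicity in this test and higher numbers for lower toxicity in this test), compound 1 (`C/C(=N\NC(N)=O)c1ccc2[nH]c(-c3ccoc3)nc2c1`) gives "not determined" (no result reported). Among the measured compounds shown here, compound 2 (`C/C(=N\NC(N)=S)c1ccc2c(c1)nc(-c1ccoc1)n2C1CCCCC1`) gives 21000 nM, the only number available so far in this test. Compound 3 (`C/C(=N\NC(N)=S)c1ccc2[nH]c(-c3ccoc3)nc2c1`) differs from compound 2 by hydrogen in place of cyclohexyl on an aromatic nitrogen, with hydrogen in place of cyclohexyl on an aromatic nitrogen. For the measured compounds named here, no measured pair shows what this change does, so the expectation is loose. The expected shift, a 1.7-fold higher number from compound 2 to compound 3 (0.22 log units; within the scatter), is small, towards lower toxicity in this test and only slightly beyond the scatter. For compound 3 the estimated value is 35000 nM, with an expected range of 10000 nM to 100000 nM.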

Compound 3, half-maximal cytotoxic concentration: 86000 nM
For compound 3 the middle estimate is 2.5-fold (0.39 log units) below the measured one; the range from low to high includes it.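

In this assay this aromatic nitrogen now has its first measured step, a 4.1-fold higher number from compound 2 to compound 3 (0.61 log units; beyond the scatter), modest and towards lower toxicity in this test. In this pair, cyclohexyl on the nitrogen is not required for a high number, and the compound bearing hydrogen reads higher. Among the compounds shown here, compound 1 gives no number, so no step to it can be read.

On these data alone, whether a methyl group, a longer chain or a chain ending in an amine on this nitrogen would give a number between those of the pair remains open, as does whether the step holds with other groups in place of furan-3-yl. No measured evidence on hand accounts for the size of this step.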